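The source may hold more compounds than are shown below. What is called first, only, known or untested is meant among the compounds shown, and "the series" means these compounds.

Compound 1 `CCCCOC1OC(=O)C(Cl)=C1Cl`: 22300 nM
Compound 2 `CC(C)(C)COC1OC(=O)C(Cl)=C1N1CCCCC1`: > 400000 nM

Both compounds were tested in an ADME assay on BEAS-2B cells (Homo sapiens) for cytotoxicity, read by MTT assay, with a stated time of 72 h; a lower number here means a stronger inhibitor, a higher number a weaker inhibitor. Compound 1 gives a number there, 22300 nM. Compound 2 gives only a limit, not a number, and it stands at the limit of > 400000 nM in this assay, at which 1 of the 2 values shown sits.

The next compound to be measured is compound 3 `CCCCOC1OC(=O)C(Cl)=C1N1CCCCC1`, which differs from compound 2 in one place: propyl in place of tert-butyl on a saturated chain carbon bound to an oxygen on a saturated carbon. This puts propyl in place of tert-butyl on a saturated chain carbon bound to an oxygen on a saturated carbon, so that neopentyloxy becomes butoxy. For the measured compounds named here, no measured pair in this small set shows what such a change does in this assay, so any expectation is uncertain. The expectation starts from compound 2, whose reading is the limit > 400000 nM. A small move toward lower numbers is expected, perhaps none beyond the scatter, and compound 3 may well return only a limit too. The expected change is an at least 1.6-fold lower number from compound 2 to compound 3 (0.20 log units; that floor lies within the scatter). For compound 3 the estimated value is 250000 nM, with an expected range from 90000 nM to 600000 nM.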

Compound 3, half-maximal inhibitory concentration: 172000 nM
Compound 3: middle estimate off by 1.5-fold (0.16 log units), on the high side; low and high end bracket the measured number.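

In this assay, propyl in place of tert-butyl on a saturated chain carbon bound to an oxygen on a saturated carbon, which turns neopentyloxy into butoxy, gives an at least 2.3-fold lower number from compound 2 to compound 3 (0.36 log units; beyond the scatter), showing that with piperidin-1-yl on the core this chain does change the reading. Compound 2 gives only a limit and not a number, so the true size of that step stays unknown: the limit of > 400000 nM in this assay, at which 1 of the 3 values shown sits.

With the butoxy chain held the same, piperidin-1-yl in place of chloro on a double-bonded ring carbon gives a 7.7-fold higher number from compound 1 to compound 3 (0.89 log units; beyond the scatter), so the change on that ring carbon can now be sized as a number. From the compounds shown here alone, each of these two changes is seen only once, so it remains open whether either step would keep its direction or size with a different chain or a different group on the ring carbon. Going by these compounds, how a longer chain such as octyloxy in place of butoxy, or a morpholin-4-yl group or a primary amine in place of piperidin-1-yl, would read in this assay also stays open.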